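From Compound 3 to Compound 4: One Group Exchanged

The compounds below may be only part of what the source reports. "The series", "measured", "known", "first", "only" and "open" are said of these compounds alone.

Of the compounds shown here, three built on a shared core have been measured in a physicochemical assay for lipophilicity, at pH 7.4; a higher number here means a more lipophilic compound, a lower number a more polar compound. Compound 1 `CCc1nc2nc(C)cc(Nc3cccc(Cl)c3)n2n1` gives 2.8 in this assay. Compound 2 `Cc1cc(Nc2ccc(S(F)(F)(F)(F)F)cc2)n2nc(C3CC3)nc2n1` gives 3.5. Compound 3 `CCc1nc2nc(C)cc(Nc3ccc(C(F)(F)F)cc3)n2n1` gives 3. Among these three numbers compound 3 stands second highest; its nearest neighbour is compound 1, whose value lies within the usual scatter of that of compound 3, while compound 2 sits furthest away, beyond the scatter.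

Compound 4 `CSc1nc2nc(C)cc(Nc3ccc(C(F)(F)F)cc3)n2n1` has not yet been measured. It differs from compound 3 in a single place: methylsulfanyl in place of ethyl on an aromatic carbon. Going by the values given here, no pair of measured compounds shows this exchange, so nothing in the data fixes the size of the step. Since compound 3 and compound 1, which differ elsewhere, already lie within the scatter of each other, a small step at most seems the reasonable expectation. A modest move downward, hardly beyond the scatter, is expected: a number 0.30 log units lower from compound 3 to compound 4 (within the scatter). Compound 4 is therefore estimated at 2.7, with a range from 2.3 to 3.1.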

Compound 4, distribution coefficient: 3.2
The estimate for compound 4 lay 0.50 log units below the measured number; measured number above the stated range.
By their numbers in this assay, from the lowest: compounds 1, 3, 4 and 2 (each within the scatter of the next, the first and the last beyond it).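

In this assay, going by these compounds alone, the first reading at this position, on an aromatic carbon between two ring nitrogen atoms, is methylsulfanyl in place of ethyl, with a number 0.20 log units higher from compound 3 to compound 4 (within the scatter). The exchange keeps the count of 2 heavy atoms but brings in a sulfur and 1 hydrogen-bond acceptor, and even so the two compounds remain within the scatter of each other. No measurement shown here offers an explanation for this result.

This single pair leaves open whether the same exchange would give a similar step with a different group elsewhere on the shared core. It also leaves open how this assay would respond at this position to an amine, a methoxy group or a longer chain.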